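Branched substituents on the cyanoguanidine in a blood-pressure model

A few compounds are considered here, and "the series" means these few. Any claim that something is new, unique, unknown or untested is made for them only; others in the source may bear on it.

Measured compounds:
compound 1, `CC(C)/N=C(\NC#N)Nc1cccnc1`: 2.5 mg/kg
compound 2, `CC(C)C(/N=C(\NC#N)Nc1cccnc1)C(C)C`: 5 mg/kg

Of the compounds shown here, two share a core and have been tested in a functional assay on the whole organism (blood, strain Wistar-Okamoto) with Rattus norvegicus as the target, with a stated time of 5 days; a higher number here means that more compound is needed for the effect, a lower number that less compound is needed. Compound 1, `CC(C)/N=C(\NC#N)Nc1cccnc1`, gives 2.5 mg/kg in this assay. Compound 2, `CC(C)C(/N=C(\NC#N)Nc1cccnc1)C(C)C`, gives 5 mg/kg, and the gap between compound 1 and compound 2 lies within the usual scatter, so neither can be said to stand apart from the other. Compound 1 has the lowest number of the two, but only nominally.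

Compound 3, `CCC(C)(CC)/N=C(\NC#N)Nc1cccnc1`, has not yet been measured. Relative to compound 1, the change is 1-ethyl-1-methylpropyl in place of isopropyl on a double-bonded nitrogen. Since compound 2, which also carries a larger branched group at the same place, gives 5 mg/kg, compound 3 is expected to behave similarly, and the step from compound 1 is estimated at a 2.0-fold higher number from compound 1 to compound 3 (0.30 log units; within the scatter), pointing toward a higher number, though likely within the scatter. For compound 3 the estimated minimum effective dose is 5 mg/kg, with a range from 2 mg/kg to 12 mg/kg.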

Compound 3, minimum effective dose: 0.5 mg/kg
Compound 3: middle estimate off by 10-fold (1.00 log units), on the high side, outside the stated range (below it).
By their numbers in this assay, from the lowest: compound 3; then compounds 1 and 2 (each within the scatter of the next).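

In this assay, for the compounds shown here, the place on the double-bonded nitrogen can shift the number beyond the scatter: 1-ethyl-1-methylpropyl in place of isopropyl gives a 5.0-fold lower number from compound 1 to compound 3 (0.70 log units; beyond the scatter) in the first step here that clears it. A larger branched group does not by itself bring the number down, as compound 2, which also carries one at this place, gives 5 mg/kg while compound 3 gives 0.5 mg/kg in the same test. Nothing measured here accounts for this difference between the two branched groups.

From the compounds shown here alone, it remains open whether a tert-butyl group, a straight hexyl chain or a cyclohexyl ring at this place would give a number closer to that of compound 3 or that of compound 1. Going by these compounds, the shared core is also constant throughout, so whether 1-ethyl-1-methylpropyl gives a similar step on another core is unknown.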